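This account rests on a few compounds, and the source may have more. Where it says the series, first, only, none or still open, it means among the compounds named here.

Compound 3 `O=C1N=C(C2C(=O)c3ccccc3C2=O)CC(c2ccc([N+](=O)[O-])cc2)N1` carries a 4-nitrophenyl group on a saturated ring carbon of the shared core. In a functional assay on the whole organism for inhibition, with Mus musculus as the target, in the writhing test, with a stated time of 15 min, at a dose of 10 mg/kg (a higher number here means more inhibition at the dose given (going by the name of the read-out), a lower number less inhibition), compound 3 gives 38%. Two close relatives are measured in the same test: compound 1 `O=C1N=C(C2C(=O)c3ccccc3C2=O)CC(c2ccccc2[N+](=O)[O-])N1` gives 35%, and compound 2 `O=C1N=C(C2C(=O)c3ccccc3C2=O)CC(c2ccccc2)N1` gives 31%. Compound 3 holds the largest of the three numbers, but a number 3 percentage points higher from compound 1 to compound 3 (within the scatter) and a number 7 percentage points higher from compound 2 to compound 3 (within the scatter) are both within the usual scatter, as is a number 4 percentage points lower from compound 1 to compound 2 (within the scatter); on these numbers the three compounds cannot be told apart.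

Compound 4 `O=C1N=C(C2C(=O)c3ccccc3C2=O)CC(/C=C/c2ccccc2)N1` is not yet measured. Its difference from compound 3 is this: 2-phenylethenyl in place of 4-nitrophenyl on a saturated ring carbon

Within the data shown here, none of the measured steps covers this change. They only add, remove or move a nitro group on the aromatic ring, and each time the read-out stayed within the scatter. Among the measured compounds shown here, the 2-phenylethenyl group is a new kind of replacement, so no measured step points to a shift in either direction. The expected step is therefore a number 5 percentage points lower from compound 3 to compound 4 (within the scatter), no larger than the scatter. Compound 4 is expected to give 33%, with a range from 18% to 48%.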

Compound 4, a percentage reported as inhibition, in the whole organism at one dose (the size of the read-out at that dose, not a potency): 16%
For compound 4 the middle estimate is 17 percentage points above the measured one, outside the stated range (below it).
By their numbers in this assay, from the lowest: compound 4; then compounds 2, 1 and 3 (each within the scatter of the next).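

The position is not indifferent to what it carries. In this assay, the read-out changed beyond the scatter with 2-phenylethenyl in place of each of the three aryl groups, giving steps (a number 22 percentage points lower from compound 3 to compound 4 (beyond the scatter)), (a number 19 percentage points lower from compound 1 to compound 4 (beyond the scatter)) and (a number 15 percentage points lower from compound 2 to compound 4 (beyond the scatter)), whereas adding, removing or moving the nitro group on the aromatic ring had produced no change that could be told from scatter. The last of these steps is the simplest comparison, since phenyl and 2-phenylethenyl both carry an unsubstituted aromatic ring of carbon only, yet nothing available here explains the lower number.

The compounds shown leave open whether the loss goes with the double bond itself or with the longer group, a question that a saturated 2-phenylethyl group could help to separate, while a small methyl group would show how much the position needs an aromatic ring at all. They also leave open whether compound 4 would catch up with the others at a different dose, since each number here comes from a single dose and is not a potency.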